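This account rests on a few compounds, and the source may have more. Where it says the series, first, only, none or still open, it means among the compounds named here.

Of the compounds shown here, two on one shared core have been read so far in a functional assay on CWR22R cells (Homo sapiens) for antiproliferative activity, with a stated time of 96 h (a higher number here means a weaker inhibitor, a lower number a stronger inhibitor), and give only a rough frame. Compound 1 (`Cc1cc(=O)oc2cc(OCC(=O)c3cc(C(F)(F)F)cc(C(F)(F)F)c3)ccc12`) gives 930 nM as the lower number. Compound 2 (`Cc1cc(=O)oc2cc(OCC(=O)c3ccc(C(C)(C)C)cc3)ccc12`) gives 22300 nM as the higher of the two, making it the weaker inhibitor, and the gap to compound 1 lies beyond the scatter.

Among the compounds with values here, no step between measured compounds differing in one place is available, so the size of the next change cannot be read directly. Compound 3 (`Cc1cc(=O)oc2cc(OCC(=O)c3ccc(F)cc3)ccc12`) comes from compound 2 through one change: fluoro in place of tert-butyl on an aromatic carbon with fluoro in place of tert-butyl on an aromatic carbon, para to a large group. The rest of the structure stays the same.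

Compound 2 at 22300 nM stands at the high end of the numbers seen, so a move toward a lower number is expected, modestly beyond the scatter, though no change beyond the scatter remains possible. The estimated step is a 2.5-fold lower number from compound 2 to compound 3 (0.39 log units; beyond the scatter) (a moderate drop). In this assay the estimate for compound 3 is 9000 nM (expected range 2500 nM to 30000 nM).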

Compound 3, half-maximal inhibitory concentration: > 100000 nM
Compound 3: a limit, no number; the forecaster's own chance of this, stated with the estimate: 10%; at least 11-fold (1.04 log units) between middle value and limit.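

Compound 3 gives only a limit in this assay, > 100000 nM, and not a number. Fluoro in place of tert-butyl gives an at least 4.4-fold higher number from compound 2 to compound 3 (0.65 log units; beyond the scatter), the first single-place step in the series, and it shows that this aromatic carbon, para to a large group, is sensitive to the choice of substituent: of the two groups compared here, the four-carbon tert-butyl keeps a measurable value and the lone fluoro does not. The step can be read only as a minimum, and its full size remains unknown: the limit of > 100000 nM in this assay, at which 1 of the 3 values shown sits.

Within the data shown here, this single pair cannot separate the effect of group size from any other difference between tert-butyl and fluoro, and compound 1 differs from compound 2 in more than one place, so it gives no step at this position. From the compounds shown here alone, it also remains open whether an isopropyl group, a methoxy group or an amine at the same carbon would give a value nearer that of compound 2 or would also end at a limit.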